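A few compounds are considered here, and "the series" means these few. Any claim that something is new, unique, unknown or untested is made for them only; others in the source may bear on it.

Measured compounds: compound 1 `CC1=CC[C@H](C(C)(C)NC(=S)N/N=C/c2ccc(F)cc2)CC1`, compound 2 `CC1=CC[C@H](C(C)(C)NC(=S)N/N=C/c2ccccc2Cl)CC1`, compound 3 `CC1=CC[C@H](C(C)(C)NC(=S)N/N=C/c2cccc(Cl)c2)CC1`.

In a functional assay on K562 cells (Homo sapiens) for inhibition, read by sulforhodamine B assay, with a stated time of 48 h (a lower number here means a stronger inhibitor of growth, a higher number a weaker inhibitor of growth), compound 1 gives only a limit, > 100000 nM. Compound 2 gives 5600 nM and compound 3 gives 5400 nM; the two sit within the scatter of each other (a 1.0-fold lower number from compound 2 to compound 3 (0.02 log units; within the scatter)). Compound 3 therefore stands at the low end of the two numbers shown, the third value being a limit (the limit of > 100000 nM in this assay, at which 1 of the 3 values shown sits).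

Compound 4 `CC1=CC[C@H](C(C)(C)NC(=S)N/N=C/c2ccc(Cl)cc2)CC1` differs from compound 3 by 4-chlorophenyl in place of 3-chlorophenyl on a carbon with a double bond to nitrogen. Among the measured compounds shown here, the steps that bear on it are an at least 17-fold lower number from compound 1 to compound 2 (1.25 log units; beyond the scatter) and an at least 18-fold lower number from compound 1 to compound 3 (1.26 log units; beyond the scatter), both large, whereas a 1.0-fold lower number from compound 2 to compound 3 (0.02 log units; within the scatter) shows no step beyond the scatter. For the measured compounds named here, the only measured compound carrying a 4-substituted phenyl is compound 1, whose value is a limit, so a weaker result than compound 3 is expected, possibly again a limit. Compound 4 is estimated at 25000 nM in this assay, with a range from 5000 nM to 100000 nM, which would be a step of a 4.6-fold higher number from compound 3 to compound 4 (0.67 log units; beyond the scatter).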

Compound 4, concentration for 50% growth inhibition: 300 nM
Estimate against measurement, compound 4: 83-fold (1.92 log units) above; the measured number lies below the stated range.
By their numbers in this assay, from the lowest: compound 4; then compounds 3 and 2 (each within the scatter of the next). At a limit, above all of these: compound 1.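

In this assay, among the compounds shown here, 4-chlorophenyl on a carbon with a double bond to nitrogen stands apart from the two chlorophenyl isomers, which the earlier compounds did not separate: an 18-fold lower number from compound 3 to compound 4 (1.26 log units; beyond the scatter) and a 19-fold lower number from compound 2 to compound 4 (1.27 log units; beyond the scatter) are both large. A 4-substituted phenyl alone therefore does not give a weak result, and chloro in place of fluoro on an aromatic carbon gives an at least 330-fold lower number from compound 1 to compound 4 (2.52 log units; beyond the scatter). This step is read against a limit held by compound 1: the limit of > 100000 nM in this assay, at which 1 of the 4 values shown sits.

On these data alone, whether 4-bromophenyl or 4-methoxyphenyl would follow 4-chlorophenyl remains open. So does the outcome with an amine or a carboxylic acid on the phenyl.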